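This account rests on a few compounds, and the source may have more. Where it says the series, first, only, none or still open, it means among the compounds named here.

Three compounds have so far been measured in an in vitro functional assay on HEK285-7 cells for antagonist activity at prostaglandin D2 receptor 2 (Homo sapiens), read by BRET and beta-arrestin recruitment; a lower number here means a smaller maximal response, a higher number a larger maximal response:

Compound 1 `NS(=O)(=O)c1ccc(-c2nc(C(c3ccc(F)cc3)c3ccc(F)cc3)sc2CC(=O)O)cc1`: 80%
Compound 2 `O=C(O)Cc1sc(C(c2ccc(F)cc2)c2ccc(F)cc2)nc1-c1ccncc1`: 80%
Compound 3 `O=C(O)Cc1sc(C(c2ccc(F)cc2)c2ccc(F)cc2)nc1-c1cc(F)nc(F)c1`: 80%

All three share one core and differ only in the aromatic ring attached to an aromatic carbon of that core. Compound 3 stands level with compounds 1 and 2; none of the three values can be told apart from the others. The steps show this directly: no change at the digits printed from compound 1 to compound 2 (within the scatter), no change at the digits printed from compound 1 to compound 3 (within the scatter) and no change at the digits printed from compound 2 to compound 3 (within the scatter). Exchanging a 4-sulfamoylphenyl ring for a pyridin-4-yl or a 2,6-difluoropyridin-4-yl ring, or one pyridine for the other, left the maximal response where it was.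

Compound 4 `O=C(O)Cc1sc(C(c2ccc(F)cc2)c2ccc(F)cc2)nc1-c1ccc(Cl)cc1` continues this series of ring swaps. The change from compound 3 is 4-chlorophenyl in place of 2,6-difluoropyridin-4-yl on an aromatic carbon. Every measured step that bears on it is a swap of one aromatic ring for another at this same aromatic carbon, and each of those steps stayed within the scatter. The expectation is therefore a step of no change at the digits printed from compound 3 to compound 4 (within the scatter) in this assay, with no change beyond the scatter in either direction. Compound 4 is estimated to give 80%, with a range from 68% to 92%.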

Compound 4, largest response reached (reported as efficacy), in percent of the reference or control that the assay uses: 80%
For compound 4 middle estimate and measured number coincide at the digits printed; measured number inside the range.
By their numbers in this assay, from the lowest: compounds 1, 2, 3 and 4 (each within the scatter of the next).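

Measured in this assay, the swap to 4-chlorophenyl gives no change at the digits printed from compound 3 to compound 4 (within the scatter) and no change at the digits printed from compound 2 to compound 4 (within the scatter), so at this aromatic carbon a ring of carbon only, with no hydrogen-bond donor or acceptor in the entering group, serves just as the two pyridine rings do, and a ring nitrogen is not needed to hold this maximal response. Chloro in place of sulfamoyl on the same phenyl ring gives no change at the digits printed from compound 1 to compound 4 (within the scatter), which shows that the sulfamoyl group is not needed either, and that a single chlorine atom on that ring does as well. No accompanying measurement explains why the response holds across these different rings.

On these data alone, every group tested here is a six-membered aromatic ring, so it remains open whether the response would hold with a non-aromatic group at this carbon, such as a cyclohexyl ring, a morpholine, an amine or a short alkyl chain. Because the four compounds cannot be told apart in this assay, they also leave open which change at this position, or at the carboxymethyl group, would move the maximal response at all.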